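A few compounds are considered here, and "the series" means these few. Any claim that something is new, unique, unknown or untested is made for them only; others in the source may bear on it.

Compound 3 `Nc1ncnn2c([C@@H]3O[C@H](CO)[C@@H](O)[C@H]3O)cc(-c3ccc(F)cc3)c12` gives 65600 nM in a functional assay on CAPAN-1 cells (Homo sapiens) for antiproliferative activity, with a stated time of 72 h (a higher number here means a weaker inhibitor, a lower number a stronger inhibitor), the highest of the three numbers recorded. Compound 2 `Nc1ncnn2c([C@@H]3O[C@H](CO)[C@@H](O)[C@H]3O)cc(C#Cc3ccccc3)c12` gives 37700 nM, and compound 1 `Nc1ncnn2c([C@@H]3O[C@H](CO)[C@@H](O)[C@H]3O)cc(C#Cc3cccs3)c12` gives 32000 nM; the step of a 1.7-fold higher number from compound 2 to compound 3 (0.24 log units; within the scatter) stays within the scatter, while the step of a 2.1-fold higher number from compound 1 to compound 3 (0.31 log units; beyond the scatter) lies just beyond it. Compound 4 `Nc1ncnn2c([C@@H]3O[C@H](CO)[C@@H](O)[C@H]3O)cc(-c3ccccc3F)c12` differs from compound 3 by 2-fluorophenyl in place of 4-fluorophenyl on an aromatic carbon. Going by the values given here, no measured step changes where a fluorine sits: the step of a 1.2-fold higher number from compound 1 to compound 2 (0.07 log units; within the scatter) compares two groups on a triple-bonded carbon and stays within the scatter, and the other two steps exchange a whole side group. On that basis, a step of a 1.1-fold lower number from compound 3 to compound 4 (0.04 log units; within the scatter) is expected, with no move beyond the scatter in either direction. Compound 4 is therefore estimated at 60000 nM, with a range from 25000 nM to 150000 nM.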

Compound 4, half-maximal inhibitory concentration: > 100000 nM
Compound 4: no number, only a limit; the forecaster's own chance of this, stated with the estimate: 15%; middle value at least 1.6-fold (0.22 log units) from the limit.
By their numbers in this assay, from the lowest: compounds 1, 2 and 3 (each within the scatter of the next, the first and the last beyond it). At a limit, above all of these: compound 4.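

In this assay compound 4 reads > 100000 nM, which is a limit of the assay and not a number. Moving the fluorine to give 2-fluorophenyl in place of 4-fluorophenyl yields an at least 1.5-fold higher number from compound 3 to compound 4 (0.18 log units; that floor lies within the scatter), so this floor alone does not establish a real change. Against the ethynyl-bearing compounds the separation is clearer: an at least 2.6-fold higher number from compound 2 to compound 4 (0.42 log units; beyond the scatter) and an at least 3.1-fold higher number from compound 1 to compound 4 (0.49 log units; beyond the scatter).

On these data alone, how far compound 4 lies past its limit remains unknown. Also open, as far as these compounds go, is whether a chlorine or a methoxy group in place of the fluorine would follow 4-fluorophenyl or 2-fluorophenyl.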